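This account rests on a few compounds, and the source may have more. Where it says the series, first, only, none or still open, it means among the compounds named here.

Measured so far in the same lipophilicity assay:
compound 1 `COc1c(OC)c(OC(=O)C(C)(C)C)c2c(Cl)cccc2c1OC(=O)C(C)(C)C` gives 6.1;
compound 2 `CCC(=O)Oc1c(OC)c(OC)c(OC(=O)CC)c2cc(Cl)ccc12` gives 4.3;
compound 3 `COc1c(OC)c(OC(=O)C(C)(C)C)c2c(OC)cccc2c1OC(=O)C(C)(C)C` gives 5.6.

Among the compounds with values here, in a physicochemical assay for lipophilicity (a higher number here means a more lipophilic compound, a lower number a more polar compound), the only measured pair that differs in one place is compound 1 and compound 3, where the move is methoxy in place of chloro on an aromatic carbon and the step is a number 0.50 log units lower from compound 1 to compound 3 (beyond the scatter). Compound 2 stands lowest of the three numbers; how its core differs from that of compound 1 is not broken down here, and the two are set apart by more than a single change.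

Compound 4 `CCC(=O)Oc1c(OC)c(OC)c(OC(=O)CC)c2cc(OC)ccc12` is the unmeasured analogue of compound 2, and differs from it by methoxy in place of chloro on an aromatic carbon. Within the data shown here, this is the same kind of change as the one from compound 1 to compound 3, but not the same: there the replaced group sits ortho to a fused ring and meta to a fused ring, whereas in compound 4 it sits meta to a fused ring and para to a fused ring.

Among the measured compounds shown here, on the sole precedent a number 0.50 log units lower from compound 1 to compound 3 (beyond the scatter), compound 4 is expected to show a step of a number 0.50 log units lower from compound 2 to compound 4 (beyond the scatter) in this assay. The estimated value of compound 4 is 3.8, expected to fall between 3.3 and 4.3.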

Compound 4, partition coefficient: 3.28
Estimate against measurement, compound 4: 0.52 log units above; measured number outside the range, below it.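

In this assay, methoxy in place of chloro gives a lower number in both cores: the new step is a number 1.02 log units lower from compound 2 to compound 4 (beyond the scatter) and stands against the earlier one, a number 0.50 log units lower from compound 1 to compound 3 (beyond the scatter), so the direction carried from one core to the other while the size did not. This does not show what sets the size of the step, since the two pairs differ both in their ester groups and in where the change sits, here meta to a fused ring and para to a fused ring, and two pairs cannot separate those differences. Nothing available here bears on why the size differs between the two cores.

The compounds shown leave open whether the same direction would hold at other places on the ring or with other ester groups on either core. They also leave open how an amine or a carboxylic acid in place of the chloro would read in this series.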